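Adding a Second Methoxy Group to Compound 3

This account rests on a few compounds, and the source may have more. Where it says the series, first, only, none or still open, it means among the compounds named here.

Measured so far:
compound 1, `COc1ccc(/C=C/C2CC(=O)C=CO2)cc1OC`, gives 130 uM
compound 2, `COc1cc(/C=C/C2CC(=O)C=CO2)cc(OC)c1OC`, gives 149 uM
compound 3, `COc1ccc(/C=C/C2CC=CC(=O)O2)cc1`, gives 25.5 uM

All three were tested in a functional assay on MCF7 cells (Homo sapiens) for inhibition, read by sulforhodamine B assay, with a stated time of 48 h; on this read-out higher numbers stand for weaker inhibition of growth and lower numbers for stronger inhibition of growth. Compound 1 and compound 2 share one core, and the change between them is methoxy in place of hydrogen on an aromatic carbon. That change made a step of a 1.1-fold higher number from compound 1 to compound 2 (0.06 log units; within the scatter), so the two values cannot be told apart.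

Compound 3 has a different core; the difference between the two cores is not broken down here. In this assay compound 3 gives 25.5 uM, the lowest of the three numbers, and the gap to compound 1 and to compound 2 is beyond the scatter.

Compound 4, `COc1ccc(/C=C/C2CC=CC(=O)O2)c(OC)c1`, has not yet been measured. It differs from compound 3 by methoxy in place of hydrogen on an aromatic carbon. This is the same kind of change as from compound 1 to compound 2, but the surroundings are not the same: there the entering methoxy sat ortho to a methoxy group and meta to a group of 9 heavy atoms and to a methoxy group, here it sits ortho to a group of 9 heavy atoms and meta to a methoxy group.

For the measured compounds named here, the only measured example of this kind of change, from compound 1 to compound 2, stayed within the scatter, so a step of about a 1.1-fold higher number from compound 3 to compound 4 (0.04 log units; within the scatter) is expected from compound 3 to compound 4, resting on that single pair on a different core. Compound 4 is therefore estimated at 28 uM in this assay, with a likely range from 12 uM to 65 uM.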

Compound 4, concentration for growth inhibition (reported as GI): 5.4 uM
Beside the measured number, compound 4's estimate is 5.2-fold (0.71 log units) above it; the whole stated range lies above it.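

In this assay, methoxy in place of hydrogen on an aromatic carbon made a step of a 4.7-fold lower number from compound 3 to compound 4 (0.67 log units; beyond the scatter), so on this core the change goes with stronger inhibition of growth. The same kind of change therefore did not carry over unchanged from one core to the other: the same change on two cores in this assay, a 1.1-fold higher number (0.06 log units; within the scatter) from compound 1 to compound 2 and a 4.7-fold lower number (0.67 log units; beyond the scatter) from compound 3 to compound 4, 5.4-fold (0.73 log units) apart, beyond the scatter of two such steps. For the compounds shown here, this rests on only two pairs, which differ both in their core and in where the methoxy enters, so they cannot show whether the core, the place on the ring, or both lie behind the gap, and they say nothing about any further core.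

The compounds shown leave open how the core of compound 1 would respond to a methoxy entering at the place it holds in compound 4, a comparison that would help to separate the effect of the core from that of the place. They also leave open whether this step is particular to methoxy or would also appear with another group at that place, such as fluorine, a hydroxy group or an amine.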